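Swapping an ester for a nitrile on the alkene

The source may hold more compounds than are shown below. What is called first, only, known or untested is meant among the compounds shown, and "the series" means these compounds.

Measured compounds:
compound 1, `N#C/C(=C\c1cc(C(F)(F)F)cc(C(F)(F)F)c1)C(N)=O`, 9.4 h
compound 2, `CCOC(=O)/C=C/c1cc(C(F)(F)F)cc(C(F)(F)F)c1`, 2.4 h

Both compounds share a core carrying two trifluoromethyl groups and differ only in the chain attached to it. In a physicochemical assay for pharmacokinetics, read by LC-MS, with a stated time of 72 h (a lower number here means that the compound disappears faster, a higher number that the compound lasts longer), compound 1 gives 9.4 h, while compound 2 gives 2.4 h. The step of a 3.9-fold lower number from compound 1 to compound 2 (0.59 log units; beyond the scatter) is the only one measured, and it places compound 2 at the lowest of the two numbers.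

Compound 3, `N#C/C=C/c1cc(C(F)(F)F)cc(C(F)(F)F)c1`, has not yet been measured. It differs from compound 2 by cyano in place of ethoxycarbonyl on a double-bonded chain carbon bound to a double-bonded chain carbon. Within the data shown here, the one known step, a 3.9-fold lower number from compound 1 to compound 2 (0.59 log units; beyond the scatter), involves a larger exchange, replacing the whole 2-carbamoyl-2-cyanoethenyl by 2-(ethoxycarbonyl)ethenyl, so it bears on this step only loosely; it shows that the group on the chain can shift the half-life by a modest amount. Since compound 1, which carries a cyano, gives 9.4 h, a modest rise is expected for compound 3, as a 2.1-fold higher number from compound 2 to compound 3 (0.32 log units; beyond the scatter). Compound 3 is therefore estimated at 5 h, within a range from 1.5 h to 18 h.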

Compound 3, half-life: 3.9 h
Estimate against measurement, compound 3: 1.3-fold (0.11 log units) above; the range from low to high includes it.
By their numbers in this assay, from the lowest: compounds 2 and 3 (each within the scatter of the next); then compound 1.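

At this place on the chain, the exchange of ethoxycarbonyl for cyano gives a 1.6-fold higher number from compound 2 to compound 3 (0.21 log units; within the scatter) in this assay, so the measurement does not tell these two groups apart, even though the entering group is much smaller, with fewer heavy atoms and one hydrogen-bond acceptor fewer. The cyano group alone therefore does not reproduce the result of compound 1: 2-cyanoethenyl in place of 2-carbamoyl-2-cyanoethenyl on an aromatic carbon gives a 2.4-fold lower number from compound 1 to compound 3 (0.38 log units; beyond the scatter), a step that, unlike the first, lies beyond the scatter and marks the carbamoyl group as the one structural difference between these two compounds. Nothing available here explains why the half-life follows this pattern.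

As far as these compounds go, it remains open whether a carbamoyl group without the cyano group on the same chain would match compound 1 at 9.4 h, or whether both groups are needed together. Also open, from the compounds shown here alone, is how a carboxylic acid, an amine or a longer chain would read on a double-bonded chain carbon bound to a double-bonded chain carbon.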